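Moving one methoxy group in a narrow series

The source may report more compounds than this note shows. Statements on the series, on what has been measured and on what is new or still open speak of the compounds shown alone.

In a functional assay on FM3A cells (Mus musculus) for inhibition (a lower number here means a stronger inhibitor, a higher number a weaker inhibitor), compound 2 (`COc1cccc(OC/C=C(\C)CC/C=C(\C)C2=CC(=O)C(C)(C)O2)c1`) gives 45.9 ug/mL and lies within the scatter of both measured neighbours: compound 1 (`COc1cccc(OC/C=C(\C)CC/C=C(\C)C2CC(=O)C(C)(C)O2)c1`) gives 68.7 ug/mL and compound 3 (`C/C(=C\COc1ccc2ccccc2c1)CC/C=C(\C)C1=CC(=O)C(C)(C)O1`) gives 56.4 ug/mL in the same read-out. Compound 4 (`COc1ccc(OC/C=C(\C)CC/C=C(\C)C2=CC(=O)C(C)(C)O2)cc1`) differs from compound 2 by 4-methoxyphenyl in place of 3-methoxyphenyl on an oxygen on a saturated carbon and carries 4-methoxyphenyl in place of 3-methoxyphenyl on an oxygen on a saturated carbon. Among the measured compounds shown here, the one measured step (a 1.5-fold lower number from compound 1 to compound 2 (0.18 log units; within the scatter)) lies elsewhere in the molecule, so no measurement tests this change directly. With so narrow a spread, no shift beyond the scatter is expected in this assay and no direction can be favoured. The estimated step (a 1.1-fold higher number from compound 2 to compound 4 (0.04 log units; within the scatter)) is correspondingly small. Compound 4 is estimated at 50 ug/mL with an expected range from 28 ug/mL to 90 ug/mL for its measurement.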

Compound 4, half-maximal inhibitory concentration: 43.8 ug/mL
Compound 4: middle estimate off by 1.1-fold (0.06 log units), on the high side; the range from low to high includes it.
By their numbers in this assay, from the lowest: compounds 4, 2, 3 and 1 (each within the scatter of the next).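

In this assay the change to 4-methoxyphenyl in place of 3-methoxyphenyl, on an oxygen on a saturated carbon, gives a step within the scatter (a 1.0-fold lower number from compound 2 to compound 4 (0.02 log units; within the scatter)). Among the compounds shown here, this is the first direct reading at this position, and it does not separate the two groups. No available evidence accounts for this result.

The compounds shown leave open whether a group of another kind at this place, such as an amine or a carboxylic acid on the phenyl ring, would move the number beyond the scatter.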